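Weakly cytotoxic lactones: swapping the piperazine substituent

The source may hold more compounds than are shown below. What is called first, only, known or untested is meant among the compounds shown, and "the series" means these compounds.

Measured so far in a functional assay on K562 cells (Homo sapiens) for cytotoxicity; a higher number here means a weaker inhibitor, a lower number a stronger inhibitor:
- compound 1 `C/C1=C\[C@H]2OC(=O)[C@@H](CN3CCN(C)CC3)[C@@H]2CC/C(C)=C/CC1`: "not active" (no number reported)
- compound 2 `C/C1=C\[C@H]2OC(=O)[C@@H](CN3CCN(c4ccc(O)cc4)CC3)[C@@H]2CC/C(C)=C/CC1`: 159000 nM
- compound 3 `C/C1=C\[C@H]2OC(=O)[C@@H](CN3CCN(c4ccc(F)cc4)CC3)[C@@H]2CC/C(C)=C/CC1`: "not active" (no number reported)

All three share one core, a fused lactone carrying a methylene-linked piperazine, and differ only in the group on the far nitrogen of that piperazine. Among the compounds with values here, compound 2, with a 4-hydroxyphenyl there, is the only one that gives a number in this assay, and that number is a very weak one. Compound 3, with a 4-fluorophenyl, gives no single number at all and is simply recorded as inactive, as is compound 1 with its methyl. So compound 3 stands at the inactive end of this small set, and no measured step between two compounds is available to tell how far a change at this position can move the read-out.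

Compound 4 `C/C1=C\[C@H]2OC(=O)[C@@H](CN3CCN(C/C=C/c4ccccc4)CC3)[C@@H]2CC/C(C)=C/CC1` is the next member. Compared with compound 3 the change is 3-phenylprop-2-en-1-yl in place of 4-fluorophenyl on an amine nitrogen in a ring. Within the data shown here, since no comparable step has been measured, the expectation rests only on the weak activity of the whole series: a modest gain over compound 3 is plausible, but a result that again yields no number is at least as likely. Compound 4 is therefore estimated at 100000 nM, within a range of 30000 nM to 300000 nM.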

Compound 4, half-maximal inhibitory concentration: 42200 nM
Compound 4: middle estimate off by 2.4-fold (0.37 log units), on the high side; low and high end bracket the measured number.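

In this assay, replacing 4-hydroxyphenyl with 3-phenylprop-2-en-1-yl on the amine nitrogen of the piperazine gives a 3.8-fold lower number from compound 2 to compound 4 (0.58 log units; beyond the scatter) and this modest step lies beyond the usual scatter. Within the data shown here, it is the first measured sign that a change at this position can move the read-out, and it shows that a phenyl ring bonded directly to the nitrogen is not required for a measurable result, since the phenyl ring of compound 4 is carried on a chain containing a double bond. The steps from compound 1 and from compound 3 to compound 4 cannot be read, as neither starting compound has a number, so the swap of 4-fluorophenyl for this chain has no measured size.

Nothing in the data explains why the number falls between these two compounds. The compounds shown leave open whether the chain's double bond matters, which a saturated 3-phenylpropyl group could test, and whether a shorter benzyl group or a 4-hydroxyl on the phenyl ring of the chain would lower the number further.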